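This account rests on a few compounds, and the source may have more. Where it says the series, first, only, none or still open, it means among the compounds named here.

Of the compounds shown here, three built on a shared core have been tested in an ADME assay on H9c2 cells (Rattus norvegicus) for cytotoxicity; a higher number here means a weaker inhibitor, a lower number a stronger inhibitor: compound 1 `O=C(Nc1nc2cccc(Cl)c2s1)C1CC1`, compound 2 `CCc1ccc2nc(NC(=O)C3CC3)sc2c1` and compound 3 `O=C(Nc1nc2ccc(OC(F)(F)F)cc2s1)C1CC1`. Compound 1 gives > 50000 nM, which is a limit of the assay and not a number. Compound 2 gives > 50000 nM, which is again a limit. Within the data shown here, compound 3 gives 5000 nM, the only true number among the three, so there is no other number to rank it against.

The next compound is compound 4 `Cc1ccc2nc(NC(=O)C3CC3)sc2c1`. Its difference from compound 3 is methyl in place of trifluoromethoxy on an aromatic carbon.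

Among the measured compounds shown here, only one measured step bears on this change. Trifluoromethoxy in place of ethyl on an aromatic carbon gave an at least 10-fold lower number from compound 2 to compound 3 (1.00 log units; beyond the scatter). Compound 4 also loses the trifluoromethoxy and carries a small carbon group instead, so that step is expected to run in reverse, towards a higher number in this assay and beyond the scatter. Methyl itself has not been measured here, so this remains a reading by analogy with ethyl.

The expected change is a 10-fold higher number from compound 3 to compound 4 (1.00 log units; beyond the scatter). Compound 4 is estimated at 50000 nM, with an expected range from 15000 nM to 100000 nM, and the assay may well report only a limit.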

Compound 4, half-maximal inhibitory concentration: > 50000 nM
Compound 4: no number, only a limit; the forecaster's own chance of this, stated with the estimate: 65%; the middle value sits exactly at the limit.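

Among these compounds, replacing trifluoromethoxy with methyl at this position gives an at least 10-fold higher number from compound 3 to compound 4 (1.00 log units; beyond the scatter) in this assay, so with ethyl in compound 2 and now methyl in compound 4, trifluoromethoxy in compound 3 is the only one of these three groups at this position that gives a true number. From the compounds shown here alone, compound 4 gives > 50000 nM, which is a limit of the assay and not a number, so the full size of this step remains unknown. The step between compound 2 and compound 4 cannot be read, so methyl and ethyl cannot be ranked against each other, because both compounds stop at the same end of the scale: the limit of > 50000 nM in this assay, at which 3 of the 4 values shown sit.

Going by these compounds, what remains open is which part of trifluoromethoxy goes with the lower number, its oxygen or its fluorines, and a methoxy or a trifluoromethyl group at this position would begin to separate the two. On these data alone, it is also open how this assay would respond to a quite different group at this carbon, such as an amine or a carboxylic acid.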